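One Aryl Swap, With No Change Expected Beyond Scatter

The source may hold more compounds than are shown below. What is called first, only, known or untested is meant among the compounds shown, and "the series" means these compounds.

Of the compounds shown here, three have so far been measured in a functional assay, with a stated time of 150 min; on this read-out higher numbers stand for weaker inhibition and lower numbers for stronger inhibition. Compound 1 `COc1ccc(-c2nc(NN)n(C)c(=O)c2C#N)cc1` gives 56 ug/mL in this assay. Compound 2 `CCOC(=O)c1cnn(-c2nc(-c3cccc(OC)c3OC)c(C#N)c(=O)n2C)c1N` gives 69 ug/mL in this assay. Compound 3 `CSc1nc(-c2cccs2)c(C#N)c(=O)n1C` gives 87 ug/mL in this assay. The number for compound 2 lies within the usual scatter of both other values, so on this read-out the three compounds cannot be told apart.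

Compound 4 `CCOC(=O)c1cnn(-c2nc(-c3ccc(N(C)C)cc3)c(C#N)c(=O)n2C)c1N` has not yet been measured. It differs from compound 2 in one place: 4-(dimethylamino)phenyl in place of 2,3-dimethoxyphenyl on an aromatic carbon. Among the compounds with values here, no pair of measured compounds shows the effect of this kind of change, so there is no measured step to lean on. The three measured compounds differ in their aryl groups and in other parts, yet their values stay within scatter of one another, which suggests that changes of this sort move the number little. The expected change, a 1.1-fold lower number from compound 2 to compound 4 (0.03 log units; within the scatter), is therefore one that stays within the scatter. The estimated value for compound 4 is 65 ug/mL, with a range from 30 ug/mL to 140 ug/mL.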

Compound 4, half-maximal inhibitory concentration: 115 ug/mL
Estimate against measurement, compound 4: 1.8-fold (0.25 log units) below, within the range that was stated.
By their numbers in this assay, from the lowest: compounds 1, 2, 3 and 4 (each within the scatter of the next, the first and the last beyond it).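

In this assay, within the data shown here, this is the first direct look at a single change at this position: the aryl group on the aromatic carbon of the shared core is exchanged while the rest of the molecule stays fixed, and a 1.7-fold higher number from compound 2 to compound 4 (0.22 log units; within the scatter) lies within the usual scatter. On this read-out, 4-(dimethylamino)phenyl and 2,3-dimethoxyphenyl therefore cannot be told apart, even though their substituents differ in kind and in where they sit on the benzene ring. No measurement here bears on why the two groups give numbers within scatter of each other.

Among these compounds, this single step covers only two substituted aryl groups at one position. Going by these compounds, whether a plain phenyl without substituents, or a phenyl carrying a carboxylic acid, would also stay within the scatter of compound 2 remains open.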